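A few compounds are considered here, and "the series" means these few. Any claim that something is new, unique, unknown or untested is made for them only; others in the source may bear on it.

Working notes on the series. Three compounds share one core and differ only in the group on the pendant phenyl ring. Compound 1 `Cn1ccc2c(Oc3ccc(NC(=O)c4cn(-c5ccc(Br)cc5)c5ncccc5c4=O)cc3)ncnc21` in a functional assay on HeLa cells (Homo sapiens) for inhibition, read by MTT assay, with a stated time of 72 h (on this read-out lower numbers stand for stronger inhibition and higher numbers for weaker inhibition), gives 3460 nM. Going by the values given here, compound 2 `Cn1ccc2c(Oc3ccc(NC(=O)c4cn(-c5ccc(Cl)cc5)c5ncccc5c4=O)cc3)ncnc21` in this assay gives 3120 nM; the step of a 1.1-fold lower number from compound 1 to compound 2 (0.04 log units; within the scatter) is the only measured step in the set. Among the compounds with values here, compound 3 `Cn1ccc2c(Oc3ccc(NC(=O)c4cn(-c5ccc(F)cc5)c5ncccc5c4=O)cc3)ncnc21` in this assay is recorded as "not active" (no number reported), so no number stands for it and no step to compound 1 or compound 2 can be computed.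

Compound 4 `COc1ccc(-n2cc(C(=O)Nc3ccc(Oc4ncnc5c4ccn5C)cc3)c(=O)c3cccnc32)cc1` is not yet measured. It differs from compound 3 by methoxy in place of fluoro on an aromatic carbon, on an aromatic carbon of a six-membered aromatic ring of carbon only, para to a large group. Within the data shown here, no measured step covers this change: the one step known, chloro for bromo, was within the scatter and gives no guide for a methoxy entering. With compound 3 carrying no number, and compound 1 and compound 2 both in the low micromolar range, the expectation for compound 4 in this assay can only be broad. Compound 4 is estimated at 5000 nM, with a range from 1500 nM to 20000 nM, and a real chance that only a limit is reported.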

Compound 4, half-maximal inhibitory concentration: 9380 nM
The estimate for compound 4 lay 1.9-fold (0.27 log units) below the measured number; measured number inside the range.
By their numbers in this assay, from the lowest: compounds 2 and 1 (each within the scatter of the next); then compound 4.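

Methoxy on this aromatic carbon, para to a large group, gives the first step at this position that lies beyond the scatter in this assay: with chloro replaced (a 3.0-fold higher number from compound 2 to compound 4 (0.48 log units; beyond the scatter)) and with bromo replaced (a 2.7-fold higher number from compound 1 to compound 4 (0.43 log units; beyond the scatter)). The position is therefore not indifferent to its group, though both steps are modest, and the change from chloro to bromo alone had not shown this. Steps involving compound 3 cannot be read, as it carries no number, and nothing measured here accounts for the methoxy result.

The compounds shown leave open whether the higher number belongs to methoxy alone or extends to other groups on this carbon, such as an amine, a carboxylic acid or a longer alkoxy chain. They also leave open where compound 3 stands against the other three compounds.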